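This account rests on a few compounds, and the source may have more. Where it says the series, first, only, none or still open, it means among the compounds named here.

Measured so far, in a functional assay on MCF7 cells (Homo sapiens) for cytotoxicity, read by sulforhodamine B assay, with a stated time of 48 h; on this read-out higher numbers stand for lower toxicity in this test and lower numbers for higher toxicity in this test:
compound 1, `COc1cc(/C(Cl)=C/C=C(\C#N)C(=O)c2c[nH]c3ccccc23)cc(OC)c1OC`: > 100000 nM
compound 2, `COc1cc(/C(Cl)=C/C=C(\C#N)C(=O)c2c[nH]c3ccc(Br)cc23)cc(OC)c1OC`: > 100000 nM
compound 3, `COc1ccc(/C(Cl)=C/C=C(\C#N)C(=O)c2c[nH]c3ccc(Br)cc23)cc1OC`: > 100000 nM

Each of these three values is a limit of this assay, not a number. Compound 2 is known in this assay only as a limit, and the two further values are limits as well. The step that the two limits leave unreadable from compound 1 to compound 2 cannot be read, since both ends are limits. The same holds for a step that the two limits leave unreadable from compound 2 to compound 3. All three compounds sit at the limit of > 100000 nM in this assay, at which 3 of the 3 values shown sit.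

Compound 4, `COc1cc(/C(Cl)=C/C=C(\C#N)C(=O)c2c(C)[nH]c3ccccc23)cc(OC)c1OC`, is not yet measured in this assay. It differs from compound 2 in one place: 2-methyl-1H-indol-3-yl in place of 5-bromo-1H-indol-3-yl on a carbonyl carbon. Neither measured step bears on this change, and neither gives a readable size. For the measured compounds named here, with every value so far at the same limit, no direction and no size of step can be drawn from the data; the expectation is only that compound 4 behaves as the measured compounds do. Compound 4 is therefore expected to give about 150000 nM in this assay, with a range from 40000 nM to 600000 nM, most likely again reported only as a limit. The step that the limit leaves unreadable from compound 2 to compound 4 that this estimate means is expected to be none beyond the scatter.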

Compound 4, concentration lethal to 50% of the cells: > 100000 nM
Compound 4: a limit, no number; the forecaster's own chance of this, stated with the estimate: 80%; the middle value lies beyond the limit too.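

In this assay compound 4 gives > 100000 nM, a limit and not a number. For the compounds shown here, no step from compound 1 or compound 2 to compound 4 can be read. The compounds shown leave open whether any change on the shared core gives a readable value: the limit of > 100000 nM in this assay, at which 4 of the 4 values shown sit.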